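The source may report more compounds than this note shows. Statements on the series, on what has been measured and on what is new or still open speak of the compounds shown alone.

Measured compounds:
Compound 1 `COc1ccc(OC)c(/C=N/NC(=O)Nc2ccc(Oc3ccnc(-c4nncn4CCN(C)C)c3)c(F)c2)c1` gives 2930 nM in a functional assay on NCI-H460 cells (Homo sapiens) for cytotoxicity, read by MTT assay, with a stated time of 72 h; on this read-out lower numbers stand for stronger inhibition and higher numbers for weaker inhibition.
Compound 2 `COc1ccc(/C=N/NC(=O)Nc2ccc(Oc3ccnc(-c4nncn4CCN(C)C)c3)c(F)c2)c(OC)c1OC` gives 1790 nM in this assay.
Compound 3 `CN(C)CCn1cnnc1-c1cc(Oc2ccc(NC(=O)N/N=C/c3ccc(F)cc3F)cc2F)ccn1` gives 1930 nM in this assay.

Compound 3 holds the second-highest of the three numbers in this assay, but none of the three is separated from the others beyond the scatter: a 1.1-fold higher number from compound 2 to compound 3 (0.03 log units; within the scatter), and a 1.5-fold lower number from compound 1 to compound 3 (0.18 log units; within the scatter).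

Compound 4 `CN(C)CCn1cnnc1-c1cc(Oc2ccc(NC(=O)N/N=C/c3ccc(O)cc3)cc2F)ccn1` differs from compound 3 in one place: 4-hydroxyphenyl in place of 2,4-difluorophenyl on a carbon with a double bond to nitrogen. Within the data shown here, the steps that bear on this change are the three in which only the aryl group on that same carbon was exchanged, and each of them stayed within the scatter: a 1.6-fold lower number from compound 1 to compound 2 (0.21 log units; within the scatter), a 1.5-fold lower number from compound 1 to compound 3 (0.18 log units; within the scatter), a 1.1-fold higher number from compound 2 to compound 3 (0.03 log units; within the scatter). A 4-hydroxyphenyl has not been tried here, so the expectation rests only on these three exchanges, all of which left the number essentially unchanged. No step beyond the scatter is therefore expected in this assay, in either direction; the expected step is a 1.0-fold higher number from compound 3 to compound 4 (0.02 log units; within the scatter). Compound 4 is estimated to give 2000 nM, with a range from 900 nM to 4500 nM.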

Compound 4, half-maximal inhibitory concentration: 1780 nM
Beside the measured number, compound 4's estimate is 1.1-fold (0.05 log units) above it; low and high end bracket the measured number.
By their numbers in this assay, from the lowest: compounds 4, 2, 3 and 1 (each within the scatter of the next).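

In this assay, the 4-hydroxyphenyl on the carbon with a double bond to nitrogen carries a hydrogen-bond donor, which the 2,4-difluorophenyl does not, yet this exchange gives a 1.1-fold lower number from compound 3 to compound 4 (0.04 log units; within the scatter). The same holds against the two methoxy-bearing aryl groups, with a 1.0-fold lower number from compound 2 to compound 4 (0.00 log units; within the scatter) and a 1.6-fold lower number from compound 1 to compound 4 (0.22 log units; within the scatter), so all four aryl groups at this place now lie within the scatter of one another, with no exception among these compounds. Nothing available explains why the number is so insensitive to this exchange.

Going by these compounds, whether an aryl group bearing an amine or a carboxylic acid would move the number beyond the scatter remains open. So does whether replacing the aryl ring with a simple alkyl chain would do so.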